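A few compounds are considered here, and "the series" means these few. Any claim that something is new, unique, unknown or untested is made for them only; others in the source may bear on it.

Compound 1 `Cc1ccc(N2C(=O)CC(N3CCN(c4ccc(O)cc4)CC3)C2=O)cc1Cl` gives 560 nM in an assay on isolated protein for inhibition of NADP-dependent malic enzyme (Homo sapiens); on this read-out lower numbers stand for stronger inhibition and higher numbers for weaker inhibition. Compound 2 `O=C1CC(N2CCN(c3ccc(O)cc3)CC2)C(=O)N1Cc1ccccc1` carries a benzyl group in place of the 3-chloro-4-methylphenyl group on the amide-type ring nitrogen, and in this assay compound 2 gives 450 nM. That exchange amounts to a 1.2-fold lower number from compound 1 to compound 2 (0.09 log units; within the scatter), so the two measured compounds cannot be told apart on this read-out; compound 2 holds the smaller of the two numbers only in the sense that the difference to compound 1 stays inside the scatter.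

Compound 3 `O=C1CC(N2CCN(c3ccccc3O)CC2)C(=O)N1Cc1ccccc1` is the next step. It differs from compound 2 in one place: 2-hydroxyphenyl in place of 4-hydroxyphenyl on an amine nitrogen in a ring. Within the data shown here, the only measured step, the one from compound 1 to compound 2, touched the other end of the shared core and was a 1.2-fold lower number from compound 1 to compound 2 (0.09 log units; within the scatter). Among the measured compounds shown here, no measured step moves the hydroxyl on the phenyl ring of the piperazine side, so nothing here points to a shift in either direction beyond the scatter. Compound 3 is therefore expected to land near 500 nM, with a plausible range from 200 nM to 1500 nM. The expected step is a 1.1-fold higher number from compound 2 to compound 3 (0.05 log units; within the scatter).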

Compound 3, half-maximal inhibitory concentration: > 20000 nM
Compound 3 was reported as a limit; the forecaster's own chance of this, stated with the estimate: 5%; at least 40-fold (1.60 log units) between middle value and limit.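

Exchanging 4-hydroxyphenyl for 2-hydroxyphenyl on the amine nitrogen in the ring leaves the atoms and the counts of hydrogen-bond donors and acceptors unchanged, yet in this assay it gives an at least 44-fold higher number from compound 2 to compound 3 (1.64 log units; beyond the scatter). In this assay compound 3 gives > 20000 nM, which is a limit and not a number, so this step has a floor but no measured size: the limit of > 20000 nM in this assay, at which 1 of the 3 values shown sits. The earlier exchange on the amide-type ring nitrogen, a 1.2-fold lower number from compound 1 to compound 2 (0.09 log units; within the scatter), showed nothing of this kind, so among the compounds shown, the place of the hydroxyl on this phenyl ring matters far more than the choice between those two groups.

From the compounds shown here alone, it remains open whether the hydroxyl itself is needed at the 4-position, which 4-methoxyphenyl or 4-aminophenyl in place of 4-hydroxyphenyl could help to settle. The 2-hydroxyphenyl group also appears here only together with benzyl, which leaves open whether the same large step would appear with the 3-chloro-4-methylphenyl group of compound 1 on the amide-type ring nitrogen.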